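The source may hold more compounds than are shown below. What is called first, only, known or untested is meant among the compounds shown, and "the series" means these compounds.

Compound 1 `CCOC(=O)C(=O)Nc1cccccc1=O` is the starting point. For the measured compounds named here, in a functional assay on the whole organism (strain Sprague-Dawley CD) for inhibition, with Rattus norvegicus as the target, read by paw edema, at a dose of 30 mg/kg by the oral route (on this read-out higher numbers stand for a stronger effect at the one dose given and lower numbers for a weaker effect), compound 1 gives 79%, the highest of the three numbers measured so far. Compound 2 `CCOC(=O)C(=O)Nc1c(C)ccccc1=O` gives 4%, and compound 3 `CCOC(=O)C(=O)Nc1ccc(NC(=O)C(=O)OCC)c(=O)cc1` gives 61%. Both measured steps alter an aromatic carbon: a number 75 percentage points lower from compound 1 to compound 2 (beyond the scatter), and a number 18 percentage points lower from compound 1 to compound 3 (beyond the scatter).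

Compound 4 `CCOC(=O)COC(=O)C(=O)Nc1cccccc1=O` differs from compound 1 in a different part of the molecule. ethoxycarbonyl in place of methyl on a saturated chain carbon bound to an oxygen next to a carbonyl group The two measured steps therefore do not bear directly on this change, since each of them touches an aromatic carbon, while here the saturated chain carbon bound to an oxygen next to a carbonyl group is altered. The numbers give no guide to direction, and the expectation rests only on the fact that compound 1 is the best of the three. A modest drop is expected, a number 19 percentage points lower from compound 1 to compound 4 (beyond the scatter), with a wide margin. Compound 4 is estimated at 60% in this assay, within a range from 25% to 85%.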

Compound 4, a percentage reported as inhibition, in the whole organism at one dose (the size of the read-out at that dose, not a potency): 31%
Estimate against measurement, compound 4: 29 percentage points above; the range from low to high includes it.
By their numbers in this assay, from the lowest: compound 2; then compound 4; then compound 3; then compound 1.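

For the compounds shown here, until now only aromatic carbons had been changed, so this is the first sign that the chain end of the molecule matters as well. With ethoxycarbonyl in place of methyl on a saturated chain carbon bound to an oxygen next to a carbonyl group, this assay gives a number 48 percentage points lower from compound 1 to compound 4 (beyond the scatter), so the read-out is sensitive to changes at this position and this replacement is clearly not tolerated without loss. Nothing available here accounts for the loss, and its cause remains unknown.

With only one replacement at this position, the added length of the chain cannot be separated from the added ester carbonyl. As far as these compounds go, a plain propyl chain, or a carboxylic acid or an amine on the same carbon, would be needed to tell these apart, and whether any group here can match or surpass compound 1 remains open.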